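What happens when compound 2 loses its isopentyl chain

The source may hold more compounds than are shown below. What is called first, only, known or untested is meant among the compounds shown, and "the series" means these compounds.

Three compounds with a shared core, compound 1 (`CCCCOc1c(CCCC)c(O)nc2ccccc12`), compound 2 (`CC(C)CCOc1c(CCC(C)C)c(O)nc2ccccc12`) and compound 3 (`C#CCOc1c(CC#C)c(O)nc2ccccc12`), have been tested in an ADME assay on CCRF-CEM cells (Homo sapiens) for cytotoxicity, read by MTT assay, with a stated time of 72 h (a higher number here means that more compound is tolerated, a lower number that less compound is tolerated), so far. The read-out is the half-maximal cytotoxic concentration. Compound 2 gives 160000 nM in this test, and that number lies within the scatter of the other two: compound 3 gives 147000 nM here and compound 1 gives 192000 nM here. On these numbers the three cannot be told apart.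

Compound 4 (`CC(C)CCOc1cc(O)nc2ccccc12`) has not been measured yet. Set against compound 2, its change is hydrogen in place of isopentyl on an aromatic carbon (hydrogen in place of isopentyl on an aromatic carbon, ortho to a hydroxy group and ortho to an isopentyloxy group). Within the data shown here, no pair of measured compounds shows this change on its own, so there is no direct precedent. Among the measured compounds shown here, the only guide is that compound 2 at 160000 nM stays within the scatter of the other two, although their side groups differ from its own. In this assay a step no larger than the scatter is therefore expected, with no firm direction. The estimated change is a 1.1-fold higher number from compound 2 to compound 4 (0.03 log units; within the scatter) and would be too small to read as real. For compound 4 the expected value is 170000 nM within an estimated range from 85000 nM to 340000 nM in this test.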

Compound 4, half-maximal cytotoxic concentration: 115000 nM
Compound 4: the middle estimate sits 1.5-fold (0.17 log units) above what was measured, within the range that was stated.
By their numbers in this assay, from the lowest: compounds 4, 3, 2 and 1 (each within the scatter of the next).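

Among these compounds, for the first time, two compounds here differ in one place only, so a single change can be read on its own. In this assay, hydrogen in place of isopentyl on an aromatic carbon, ortho to a hydroxy group and ortho to an isopentyloxy group, gives a 1.4-fold lower number from compound 2 to compound 4 (0.14 log units; within the scatter) and therefore cannot be read as a real effect. A chain of 5 heavy atoms can thus leave this carbon without a step beyond the scatter, and nothing available bears on why the chain's presence or absence makes so little difference here.

From the compounds shown here alone, this one step says nothing about a different kind of group on the same carbon, so it remains open whether an amine, a carboxylic acid or a chain much longer than isopentyl would also stay within the scatter. Going by these compounds, it also remains open whether the same change would hold with the side groups of the other compounds, or what would happen if the isopentyloxy group itself gave way to an amine.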